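Cyclopropyl to pentan-3-yl on the ring-amine chain carbon

The source may report more compounds than this note shows. Statements on the series, on what has been measured and on what is new or still open speak of the compounds shown alone.

Measured so far in a functional assay on the whole organism for antagonist activity, with Mus musculus as the target; on this read-out lower numbers stand for an effect already at smaller amounts and higher numbers for an effect only at larger amounts of compound:
compound 1, `COc1cc(N)c(Cl)cc1NC(=O)C1CCN(CC2CC2)CC1`: > 10 mg/kg, a limit of this assay rather than a number.
compound 2, `COc1cc(N)c(Cl)cc1NC(=O)C1CCN(Cc2cccc(C)c2)CC1`: 2.4 mg/kg.
compound 3, `COc1cc(N)c(Cl)cc1NC(=O)C1CCN(Cc2ccc(Cl)cc2)CC1`: 1.2 mg/kg.

Compound 1 stands only at the limit of > 10 mg/kg in this assay, at which 1 of the 3 values shown sits, so its place is known as a bound, not a point. Compound 4, `CCC(CC)CN1CCC(C(=O)Nc2cc(Cl)c(N)cc2OC)CC1`, differs from it by pentan-3-yl in place of cyclopropyl on a saturated chain carbon bound to an amine nitrogen in a ring. The two steps that bear on this position both put an aromatic ring there: an at least 4.1-fold lower number from compound 1 to compound 2 (0.61 log units; beyond the scatter) and an at least 8.3-fold lower number from compound 1 to compound 3 (0.92 log units; beyond the scatter), while a 2.0-fold lower number from compound 2 to compound 3 (0.30 log units; within the scatter). Compound 4 carries a branched chain with no ring, so those gains need not carry over; a change of about the scatter from compound 1 is expected. Compound 4 is therefore estimated at 8 mg/kg, between 2.5 mg/kg and 25 mg/kg, an expected step of an at least 1.2-fold lower number from compound 1 to compound 4 (0.09 log units; that floor lies within the scatter).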

Compound 4, dose for half-maximal effect: > 10 mg/kg
Compound 4 gave a limit, no number; the forecaster's own chance of this, stated with the estimate: 45%; middle value at least 1.2-fold (0.09 log units) from the limit.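

Replacing the aromatic groups with pentan-3-yl gives an at least 4.1-fold higher number from compound 2 to compound 4 (0.61 log units; beyond the scatter) and an at least 8.3-fold higher number from compound 3 to compound 4 (0.92 log units; beyond the scatter), so a larger branched chain without a ring does not match compounds 2 and 3. Among these four compounds, only those with an aromatic ring in this place give a number, and none goes against this. The step between compound 1 and compound 4 cannot be read, as both stand at a limit and not a number: the limit of > 10 mg/kg in this assay, at which 2 of the 4 values shown sit.

Still open, on these data alone, is whether a saturated ring such as cyclohexyl would give a number here, or whether the aromatic ring is needed. As far as these compounds go, how far compound 4 lies beyond the limit also remains unknown.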